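A Non-Aromatic Ring Group in Compound 3

The source may hold more compounds than are shown below. What is called first, only, known or untested is meant among the compounds shown, and "the series" means these compounds.

Among the measured compounds shown here, in a functional assay on MRC5 cells (Homo sapiens) for cytotoxicity, read by MTT assay, with a stated time of 48 h (on this read-out higher numbers stand for weaker inhibition and lower numbers for stronger inhibition), compound 1 (`C[n+]1cccc(OP(=O)([O-])OC[C@H]2O[C@@H](n3cc(F)c(=O)[nH]c3=O)C[C@@H]2OC(=O)c2ccccc2)c1`) gives 5750 nM and compound 2 (`CCOC(=O)C[n+]1cccc(OP(=O)([O-])OC[C@H]2O[C@@H](n3cc(F)c(=O)[nH]c3=O)C[C@@H]2OC(=O)c2ccccc2)c1`) gives 8600 nM, so compound 2 stands level with the only other number available. For the measured compounds named here, the single measured step, a 1.5-fold higher number from compound 1 to compound 2 (0.17 log units; within the scatter), puts ethoxycarbonyl in place of hydrogen on a saturated chain carbon bound to an aromatic nitrogen. Compound 3 (`C[N+]1(C)CCC(OP(=O)([O-])OC[C@H]2O[C@@H](n3cc(F)c(=O)[nH]c3=O)C[C@@H]2OC(=O)c2ccccc2)CC1`) has not yet been measured and carries a group of 8 heavy atoms (7 carbon, 1 nitrogen; one six-membered non-aromatic ring with 1 hetero atom) in place of a group of 12 heavy atoms (9 carbon, 1 nitrogen, 2 oxygen; one six-membered aromatic ring with 1 hetero atom), on an oxygen. Going by the values given here, no measured step replaces that whole group, so the step between compound 1 and compound 2 bears on this change only loosely. A shift no larger than the scatter is therefore expected in this assay, with no firm direction, although the range must stay wide. The expected change is a 1.2-fold lower number from compound 2 to compound 3 (0.09 log units; within the scatter). For compound 3 the estimated value is 7000 nM, with an expected range of 2500 nM to 20000 nM.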

Compound 3, half-maximal inhibitory concentration: 8300 nM
Compound 3: middle estimate off by 1.2-fold (0.07 log units), on the low side; measured number inside the range.
By their numbers in this assay, from the lowest: compounds 1, 3 and 2 (each within the scatter of the next).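

In this assay the ring group on the oxygen whose other neighbours are phosphorus was exchanged for the six-membered non-aromatic ring, and the two steps read (a 1.0-fold lower number from compound 2 to compound 3 (0.02 log units; within the scatter)) and (a 1.4-fold higher number from compound 1 to compound 3 (0.16 log units; within the scatter)). Until now only aromatic ring groups had stood at this place, and these steps show that a non-aromatic ring with the same net charge of +1 as the group it replaces in compound 2 leaves the number within the scatter. Nothing at hand explains this result.

All three compounds carry a six-membered ring with 1 hetero atom at this place. The compounds shown therefore leave open whether a phenyl ring, or a chain ending in a carboxylic acid, would shift the number beyond the scatter.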